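A few compounds are considered here, and "the series" means these few. Any claim that something is new, unique, unknown or untested is made for them only; others in the source may bear on it.

Working notes on the sulfonyl series sharing the core of compound 1 `Cc1oncc1NS(=O)(=O)c1ccc(F)c2ncc(I)cc12`. In an assay for inhibition of methylcytosine dioxygenase TET2 (Homo sapiens), read by mass spectrometry, with stated times of 30 min and 1 h (on this read-out lower numbers stand for stronger inhibition and higher numbers for weaker inhibition), compound 1 gives 2100 nM. Replacing the five-membered aromatic ring on the sulfonyl sulfur by a methoxy group yields compound 2 `COS(=O)(=O)c1ccc(F)c2ncc(I)cc12`. In this assay compound 2 reaches only the limit of the assay, at > 200000 nM. The ethoxy analogue, compound 3 `CCOS(=O)(=O)c1ccc(F)c2ncc(I)cc12`, likewise returns only a limit in this assay, at > 200000 nM. Both steps away from compound 1 are large: an at least 95-fold higher number from compound 1 to compound 2 (1.97 log units; beyond the scatter) and an at least 95-fold higher number from compound 1 to compound 3 (1.97 log units; beyond the scatter). Between the two esters the step is not readable, a step that the two limits leave unreadable from compound 2 to compound 3, because both values sit at the limit of > 200000 nM in this assay, at which 2 of the 3 values shown sit. Compound 3 therefore stands at the limit, with no number of its own.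

Compound 4 `CC(C)OS(=O)(=O)c1ccc(F)c2ncc(I)cc12` extends the ester once more: methyl in place of hydrogen on a saturated chain carbon bound to an oxygen on an unsaturated carbon and a saturated chain carbon. Among the compounds with values here, the only measured step of the same kind, from the methyl ester to the ethyl ester, was unreadable, and nothing among the measured compounds suggests that a further methyl on the chain would recover what the five-membered ring supplied. The expectation for compound 4 in this assay is therefore a value again at or beyond the limit, with the step that the limit leaves unreadable from compound 3 to compound 4 expected to be unreadable. Compound 4 is estimated at 300000 nM, within 60000 nM to 1500000 nM.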

Compound 4, half-maximal inhibitory concentration: > 200000 nM
Compound 4 was reported as a limit; the forecaster's own chance of this, stated with the estimate: 85%; the middle value is on the limit's open side.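

The isopropoxy group, the third oxygen-linked chain on the sulfonyl sulfur, also does not recover what the five-membered aromatic ring supplied in this assay, with an at least 95-fold higher number from compound 1 to compound 4 (1.97 log units; beyond the scatter). For compound 4 the result is only a limit, > 200000 nM, and not a number. The steps among compound 2, compound 3 and compound 4 cannot be read, so the methyl in place of hydrogen on the saturated chain carbon gives no measurable change, and the methoxy, ethoxy and isopropoxy groups cannot be ranked: the limit of > 200000 nM in this assay, at which 3 of the 4 values shown sit.

Still open, from the compounds shown here alone, is whether the ring itself or the nitrogen that joins it to the sulfonyl sulfur accounts for the value of compound 1, 2100 nM, a question that a plain amine or an anilino group on the sulfur could separate. Going by these compounds, how far the three esters lie beyond their shared limit also stays unknown, and a longer chain such as n-butoxy would add only another reading of the same kind if it too reached the limit.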